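Swapping 4-fluorophenyl for thiophen-2-yl on a triple-bonded carbon

The source may report more compounds than this note shows. Statements on the series, on what has been measured and on what is new or still open speak of the compounds shown alone.

Compound 1 `CCCCC#Cc1cc([C@@H]2O[C@H](CO)[C@@H](O)[C@H]2O)n2ncnc(N)c12` gives 1000 nM
Compound 2 `Nc1ncnn2c([C@@H]3O[C@H](CO)[C@@H](O)[C@H]3O)cc(C#Cc3ccc(F)cc3)c12` gives 55400 nM

Among the measured compounds shown here, in a functional assay on CAPAN-1 cells (Homo sapiens) for antiproliferative activity, with a stated time of 72 h (a higher number here means a weaker inhibitor, a lower number a stronger inhibitor), compound 2 stands at 55400 nM as the higher of the two numbers, which makes it the weaker compound so far. For the measured compounds named here, one measured step bears on the next change: a 55-fold higher number from compound 1 to compound 2 (1.74 log units; beyond the scatter) is large, with 4-fluorophenyl in place of butyl on a triple-bonded carbon. The change to compound 3 `Nc1ncnn2c([C@@H]3O[C@H](CO)[C@@H](O)[C@H]3O)cc(C#Cc3cccs3)c12` is thiophen-2-yl in place of 4-fluorophenyl on a triple-bonded carbon and it trades one aromatic ring for another, with no butyl involved. A smaller step than that large one is therefore expected in this assay and a modest move toward a lower number seems likelier, though one step cannot fix the direction. The expected size is a 2.8-fold lower number from compound 2 to compound 3 (0.44 log units; beyond the scatter) by this estimate. For compound 3 the estimated value is 20000 nM with a range from 3000 nM to 80000 nM as the expected spread.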

Compound 3, half-maximal inhibitory concentration: 32000 nM
The estimate for compound 3 lay 1.6-fold (0.20 log units) below the measured number; the measured number falls inside the stated range.
By their numbers in this assay, from the lowest: compound 1; then compounds 3 and 2 (each within the scatter of the next).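

In this assay the step of a 1.7-fold lower number from compound 2 to compound 3 (0.24 log units; within the scatter) leaves thiophen-2-yl and 4-fluorophenyl indistinguishable on the triple-bonded carbon, even though a five-membered ring with sulfur has replaced a six-membered carbon ring bearing fluorine. A second aromatic ring also stands well apart from the butyl chain, with a 32-fold higher number from compound 1 to compound 3 (1.51 log units; beyond the scatter) on top of the earlier step of a 55-fold higher number from compound 1 to compound 2 (1.74 log units; beyond the scatter) in the same direction. The large gap to compound 1 is therefore not peculiar to 4-fluorophenyl, at least across these two rings.

Still open, from the compounds shown here alone, is how other groups on this carbon would compare with butyl, such as a longer chain, a chain ending in an amine, or a saturated ring like cyclohexyl. Nothing available here explains why the chain and the two rings differ.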